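Replacing 2,4-dichlorophenyl with 2-bromophenyl in compound 2

This account rests on a few compounds, and the source may have more. Where it says the series, first, only, none or still open, it means among the compounds named here.

Compound 1 `O=C1/C(=C/c2ccccc2)COC/C1=C\c1ccccc1F` gives 17600 nM
Compound 2 `O=C1/C(=C/c2ccccc2F)COC/C1=C\c1ccc(Cl)cc1Cl` gives 7900 nM
Compound 3 `COc1cc(/C=C2\COC/C(=C\c3ccccc3F)C2=O)cc(OC)c1OC` gives 6300 nM

These values come from a functional assay on A549 cells (Homo sapiens) for cytotoxicity, read by MTT assay, with a stated time of 72 h (on this read-out higher numbers stand for weaker inhibition and lower numbers for stronger inhibition), and belong to compounds with a shared core. The values of compound 2 and compound 3 lie within the usual scatter of each other, and both stand clearly apart from the higher value of compound 1. The next compound to be measured is compound 4 `O=C1/C(=C/c2ccccc2F)COC/C1=C\c1ccccc1Br`, which differs from compound 2 as follows: 2-bromophenyl in place of 2,4-dichlorophenyl on a double-bonded chain carbon bound to a double-bonded ring carbon. Among the measured compounds shown here, one measured step bears directly on this place, namely a 2.2-fold lower number from compound 1 to compound 2 (0.35 log units; beyond the scatter), where 2,4-dichlorophenyl took the place of phenyl. That step is modest. Compound 3 carries yet another group at this place and gives 6300 nM in the same assay, so the values seen there so far span little. For the measured compounds named here, no measured compound carries 2-bromophenyl, so the data offer no direct reading for it. A halogen-bearing phenyl remains in place, and no step beyond the scatter is therefore expected in this assay. The expected change is a 1.2-fold higher number from compound 2 to compound 4 (0.08 log units; within the scatter) and would be slightly upward if it shows at all. For compound 4 the value is estimated at 9500 nM (expected range 4500 nM to 20000 nM).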

Compound 4, half-maximal inhibitory concentration: 6500 nM
Compound 4: middle estimate off by 1.5-fold (0.16 log units), on the high side; the range from low to high includes it.
By their numbers in this assay, from the lowest: compounds 3, 4 and 2 (each within the scatter of the next); then compound 1.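

In this assay, placing 2-bromophenyl on the double-bonded chain carbon bound to a double-bonded ring carbon gives a 1.2-fold lower number from compound 2 to compound 4 (0.08 log units; within the scatter), so 2-bromophenyl and 2,4-dichlorophenyl cannot be told apart at this place. A single bromo on the phenyl also sets the compound apart from the unsubstituted one, with a 2.7-fold lower number from compound 1 to compound 4 (0.43 log units; beyond the scatter), a modest step that stands alongside a 2.2-fold lower number from compound 1 to compound 2 (0.35 log units; beyond the scatter), so two different halogen patterns now lead to the same modest result, although a halogen at this place is not required, as compound 3, which carries none there, gives 6300 nM. Nothing at hand explains why these groups give such similar numbers or why the plain phenyl stands apart.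

The compounds shown leave open how an amine, a carboxylic acid or a longer chain on this phenyl would read, since every group seen here is an aromatic ring with halogen or ether substituents, or none. On these data alone, the rest of the shared core is the same in all four compounds, so how a change elsewhere would read also remains open.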